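The source may report more compounds than this note shows. Statements on the series, on what has been measured and on what is new or still open speak of the compounds shown alone.

For the measured compounds named here, compound 1, with the structure `CCCC(CCC)C(=O)OC[C@H]1O[C@@H](n2cnc3c(N)ncnc32)[C@H](OC(=O)C(CCC)CCC)[C@]1(C)O`, is the only compound in this set for which a number has been recorded: in a functional assay on HT-29 cells (Homo sapiens) for inhibition, read by MTT assay, with a stated time of 48 h (on this read-out higher numbers stand for weaker inhibition and lower numbers for stronger inhibition), compound 1 gives 54600 nM, a concentration at the high end of what such assays usually report. A second compound, compound 2 with the structure `CCCC(CCC)C(=O)Nc1ncnc2c1ncn2[C@@H]1O[C@H](COC(=O)C(CCC)CCC)[C@@](C)(O)[C@H]1OC(=O)C(CCC)CCC`, was also put into this assay, but compound 2 returned "nd(insoluble)" (no result reported), no number at all, as the record states only that it could not be dissolved. Going by the values given here, with a single number in hand there is no measured step between compounds to lean on.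

Compound 3, with the structure `CCCC(CCC)C(=O)OC[C@H]1O[C@@H](n2cnc3c(N)ncnc32)[C@H](O)[C@]1(C)O`, has not yet been measured. It differs from compound 1 in one place: hydrogen in place of (1-propylbutyl)carbonyl on an oxygen on a saturated carbon. Among the compounds with values here, the data give no precedent for this change, so the size and direction of the step are open; a step from compound 1 to compound 3 of modest size in either direction, or none beyond the usual scatter, would be unsurprising. On this basis compound 3 is expected to lie near compound 1, at about 80000 nM, within a range of 20000 nM to 300000 nM, a step of a 1.5-fold higher number from compound 1 to compound 3 (0.17 log units; within the scatter) that is offered as an estimate only.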

Compound 3, half-maximal inhibitory concentration: > 200000 nM
Compound 3: a limit, no number; the forecaster's own chance of this, stated with the estimate: 30%; middle value at least 2.5-fold (0.39 log units) from the limit.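

In this assay compound 3 gives > 200000 nM, which is a limit of the assay and not a number. Replacing (1-propylbutyl)carbonyl with hydrogen on an oxygen on a saturated carbon, which turns ((1-propylbutyl)carbonyl)oxy into hydroxy, gives an at least 3.6-fold higher number from compound 1 to compound 3 (0.56 log units; beyond the scatter), so this one pair shows that the group at this place counts for the read-out and that losing it weakens inhibition of these cells. The step can be given only as a lower bound, and its true size stays unknown, because compound 3 sits at the limit of what is reported: the limit of > 200000 nM in this assay, at which 1 of the 3 values shown sits.

Going by these compounds, the pair shows only the two extremes of full (1-propylbutyl)carbonyl and bare hydroxy, so it remains open how an acetyl group, a longer chain or an amine on this oxygen would read in this assay. On these data alone, compound 2 offers no number, so any step involving it cannot be read, and whether the (1-propylbutyl)carbonyl on the other oxygen of compound 1 matters in the same way also stays open.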